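From 4-methoxy-3-nitrobenzyl to benzyl: compound 4

The source may hold more compounds than are shown below. What is called first, only, known or untested is meant among the compounds shown, and "the series" means these compounds.

In an ADME assay on J774.1 cells (Mus musculus) for cytotoxicity, read by resazurin assay, with a stated time of 48 h (on this read-out higher numbers stand for weaker inhibition and lower numbers for stronger inhibition), compound 3 (`CCCCn1cc(C(=O)NCc2ccc(OC)c([N+](=O)[O-])c2)c(=O)c2cc(F)c(N3CCC(C(N)=O)CC3)cc21`) gives > 100000 nM, which is a limit of the assay and not a number. Compound 4 (`CCCCn1cc(C(=O)NCc2ccccc2)c(=O)c2cc(F)c(N3CCC(C(N)=O)CC3)cc21`) keeps its butyl chain, and the change is phenyl in place of 4-methoxy-3-nitrophenyl on a saturated chain carbon bound to an amide-type nitrogen, or 4-methoxy-3-nitrobenzyl to benzyl. Going by the values given here, no measured step covers this place. With the same benzyl, compound 1 (`CCCn1cc(C(=O)NCc2ccccc2)c(=O)c2cc(F)c(N3CCC(C(N)=O)CC3)cc21`) gives 43700 nM and compound 2 (`NC(=O)C1CCN(c2cc3c(cc2F)c(=O)c(C(=O)NCc2ccccc2)cn3C2CC2)CC1`) gives 51200 nM as the nearest guides. Cyclopropyl in place of propyl on an aromatic nitrogen gives a 1.2-fold higher number from compound 1 to compound 2 (0.07 log units; within the scatter), so that change elsewhere in the structure adds little. A move toward stronger inhibition in this assay is therefore expected, an estimated at least 2.3-fold lower number from compound 3 to compound 4 (0.37 log units; beyond the scatter). For compound 4 the estimated value is 42000 nM, with an expected range of 19000 nM to 90000 nM.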

Compound 4, half-maximal inhibitory concentration: 47000 nM
Compound 4: the middle estimate sits 1.1-fold (0.05 log units) below what was measured, within the range that was stated.
By their numbers in this assay, from the lowest: compounds 1, 4 and 2 (each within the scatter of the next). At a limit, above all of these: compound 3.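

Compound 3 holds a limit of the assay and not a number: the limit of > 100000 nM in this assay, at which 1 of the 4 values shown sits. In this assay, going by these compounds alone, 4-methoxy-3-nitrobenzyl to benzyl gives an at least 2.1-fold lower number from compound 3 to compound 4 (0.32 log units; beyond the scatter), so this place, which no earlier step covered, does shift the read-out, though the full size of the shift stays unknown. The chain on the aromatic nitrogen shows no such shift: butyl in place of cyclopropyl gives a 1.1-fold lower number from compound 2 to compound 4 (0.04 log units; within the scatter), and butyl in place of propyl gives a 1.1-fold higher number from compound 1 to compound 4 (0.03 log units; within the scatter). From the compounds shown here alone, how 4-methoxybenzyl or 3-nitrobenzyl alone would read stays open, as does a chain longer than butyl on that nitrogen.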